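The source may report more compounds than this note shows. Statements on the series, on what has been measured and on what is new or still open speak of the compounds shown alone.

In an in vitro ADME assay on microsomes (Homo sapiens) for metabolic stability (a higher number here means that the compound lasts longer, a lower number that the compound disappears faster), compound 1 (`Cc1c2c(n3c1CCCNC[C@H](C)Nc1cc-3ccc1C(N)=O)CC(C)(C)CC2=O`) gives 0.167 h and compound 2 (`Cc1c2c(n3c1CCN(C(=O)[C@@H](N)C(C)C)C[C@@H](C)[C@H](C)Nc1cc-3ccc1C(N)=O)CC(C)(C)CC2=O`) gives 0.133 h. These two numbers lie within the usual scatter of each other, so neither compound can be said to last longer. Compound 3 (`Cc1c2c(n3c1CCN(C(=O)[C@H](C)O)C[C@@H](C)[C@H](C)Nc1cc-3ccc1C(N)=O)CC(C)(C)CC2=O`) keeps the core of compound 2 and alters one group: 1-hydroxyethyl in place of 1-amino-2-methylpropyl on a carbonyl carbon. In plain terms, 1-hydroxyethyl takes the place of 1-amino-2-methylpropyl on a carbonyl carbon. For the measured compounds named here, no pair of measured compounds shows what a swap of this kind does, so the expectation rests on thin evidence and stays close to the starting value of compound 2 at 0.133 h. The expected move is a 1.4-fold higher number from compound 2 to compound 3 (0.13 log units; within the scatter), a slight upward step that stays within the scatter. For compound 3 the estimated half-life is 0.18 h, with an expected range of 0.09 h to 0.4 h.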

Compound 3, half-life: 0.25 h
The estimate for compound 3 lay 1.4-fold (0.14 log units) below the measured number; the measured number falls inside the stated range.
By their numbers in this assay, from the lowest: compounds 2, 1 and 3 (each within the scatter of the next).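

In this assay, for the compounds shown here, this is the first measured swap on this carbonyl carbon, and it gives a 1.9-fold higher number from compound 2 to compound 3 (0.27 log units; within the scatter). Replacing 1-amino-2-methylpropyl with 1-hydroxyethyl therefore cannot be told apart from repeat measurement, even though the entering group has fewer heavy atoms and carries oxygen rather than nitrogen, while the hydrogen-bond donor and acceptor counts stay the same. Nothing measured here offers an explanation for this result.

Going by these compounds alone, with only this one pair, the loss of the nitrogen cannot be separated from the reduction in heavy atoms, since both differ at once. As far as these compounds go, how a carboxylic acid or a plain ethyl group would behave on the same carbonyl carbon also remains open, as does whether any group here could move the half-life beyond the usual scatter.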